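This account rests on a few compounds, and the source may have more. Where it says the series, first, only, none or still open, it means among the compounds named here.

Three compounds of the series have numbers in a functional assay on A-375 cells (Homo sapiens) for antiproliferative activity, read by MTT assay, with a stated time of 24 h; a lower number here means a stronger inhibitor, a higher number a weaker inhibitor. Compound 1 `COc1cc(OC)c(-c2coc3cc(OCC=C(C)C)ccc3c2=O)cc1OC` gives 1580 nM, compound 2 `C#CCOc1ccc2c(=O)c(-c3cc(OC)c(OC)cc3OC)coc2c1` gives 3680 nM, and compound 3 `COc1cc(OC)c(-c2coc3cc(OCc4ccccc4C)ccc3c2=O)cc1OC` gives 1360 nM. Compound 2 stands highest of the three; the nearest step to it is a 2.3-fold higher number from compound 1 to compound 2 (0.37 log units; beyond the scatter) and the furthest is a 2.7-fold lower number from compound 2 to compound 3 (0.43 log units; beyond the scatter). Compound 4 `COc1cc(OC)c(-c2coc3cc(OCc4cccc(C(F)(F)F)c4)ccc3c2=O)cc1OC` is not yet measured and differs from compound 2 by 3-(trifluoromethyl)phenyl in place of ethynyl on a saturated chain carbon bound to an oxygen on an aromatic ring. The step of a 2.7-fold lower number from compound 2 to compound 3 (0.43 log units; beyond the scatter) bears most directly on this change, since it also places a 2-methylphenyl on the same saturated chain carbon, and a 1.2-fold lower number from compound 1 to compound 3 (0.07 log units; within the scatter) shows 2-methylphenyl and 2-methylprop-1-en-1-yl within the scatter of each other. A modest downward step is therefore expected, a 2.5-fold lower number from compound 2 to compound 4 (0.39 log units; beyond the scatter). For compound 4 the estimated value is 1500 nM, with a range of 600 nM to 4000 nM.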

Compound 4, half-maximal inhibitory concentration: 1140 nM
The estimate for compound 4 lay 1.3-fold (0.12 log units) above the measured number; measured number inside the range.
By their numbers in this assay, from the lowest: compounds 4, 3 and 1 (each within the scatter of the next); then compound 2.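

On the saturated chain carbon bound to an oxygen on an aromatic ring, the downward step away from ethynyl is not confined to 2-methylphenyl: 3-(trifluoromethyl)phenyl also gives one (a 3.2-fold lower number from compound 2 to compound 4 (0.51 log units; beyond the scatter)). Against the other two groups, 3-(trifluoromethyl)phenyl shows no separation (a 1.2-fold lower number from compound 3 to compound 4 (0.08 log units; within the scatter); a 1.4-fold lower number from compound 1 to compound 4 (0.14 log units; within the scatter)), so only compound 2 stands apart. No measurement available here explains this difference.

Still open, as far as these compounds go, is whether an amine or a carboxylic acid on the benzene ring, or a longer saturated chain in place of that ring, would move the number beyond the scatter of compound 1, compound 3 and compound 4.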